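Ethoxy for methyl on a weakly antiproliferative core

The source may hold more compounds than are shown below. What is called first, only, known or untested is meant among the compounds shown, and "the series" means these compounds.

Measured compounds:
compound 1 `N#CC1=C(N)Oc2c(c3nc4ccccc4nc3c3ccccc23)C12C(=O)N(Cc1cnnn1-c1cc(Cl)ccc1Cl)c1ccccc12`, > 50000 nM
compound 2 `Cc1ccccc1-n1nncc1CN1C(=O)C2(C(C#N)=C(N)Oc3c(N)cc4nc5ccccc5nc4c32)c2ccccc21`, 31700 nM

Of the compounds shown here, two share a core and have been tested in a functional assay on A549 cells (Homo sapiens) for antiproliferative activity, read by MTT assay, with a stated time of 48 h; a lower number here means a stronger inhibitor, a higher number a weaker inhibitor. Among the measured compounds shown here, compound 1 reached no number at all: its > 50000 nM is a limit of the assay, not a value, and the limit of > 50000 nM in this assay, at which 1 of the 2 values shown sits, marks the one compound that sits there. For the measured compounds named here, compound 2 is therefore the only compound with an actual number, giving 31700 nM in this assay, which is weak inhibition. Going by the values given here, with no step between two measured compounds available, nothing can yet be said about how any change on this core moves the number.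

Compound 3 `CCOc1ccccc1-n1nncc1CN1C(=O)C2(C(C#N)=C(N)Oc3c(N)cc4nc5ccccc5nc4c32)c2ccccc21` is not yet measured. It differs from compound 2 in one place, (ethoxy in place of methyl on an aromatic carbon). The change is small and sits on the same aromatic carbon, so the step from compound 2 to compound 3 is expected to be a 1.1-fold lower number from compound 2 to compound 3 (0.02 log units; within the scatter), no further than the usual scatter and in no clear direction. Compound 3 is therefore estimated at 30000 nM in this assay, with a likely range from 10000 nM to 90000 nM.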

Compound 3, half-maximal inhibitory concentration: > 50000 nM
Compound 3: no number, only a limit; the forecaster's own chance of this, stated with the estimate: 30%; middle value at least 1.6-fold (0.22 log units) away from the limit.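

In this assay, among the compounds shown here, going from 2-methylphenyl to 2-ethoxyphenyl gives the first readable step on this core: an at least 1.5-fold higher number from compound 2 to compound 3 (0.19 log units; that floor lies within the scatter). Compound 3 gives > 50000 nM, which is a limit of the assay and not a number, so this step has a known floor but no known size. Ethoxy on this aromatic carbon, ortho to a large group, therefore brings no lower number than methyl, and compound 2 remains the only compound here with an actual value, while the new result joins the ceiling of the measurement: the limit of > 50000 nM in this assay, at which 2 of the 3 values shown sit.

The compounds shown leave open whether a methoxy group, a hydroxyl group or an amine on this same aromatic carbon would give a lower number than compound 2 or would also run to the limit. They also cannot separate the part played by the ethoxy oxygen from the part played by the longer chain, a question that a propyl group, which holds no oxygen, could help to answer.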